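The compounds below may be only part of what the source reports. "The series", "measured", "known", "first", "only" and "open" are said of these compounds alone.

Measured so far:
- compound 1 `COc1nn(Cc2cccc([N+](=O)[O-])c2)c(=O)o1`: 7%
- compound 2 `COc1nn(Cc2cccc(C#N)c2)c(=O)o1`: "not active" (no number reported)

Both compounds share a core and differ only in the group on the benzene ring. In an assay on COS-7 cells for inhibition of Fatty-acid amide hydrolase 1 (Homo sapiens), read by scintillation counting, with a stated time of 10 min, tested at 10 uM (a lower number here means less inhibition, a higher number more inhibition at the concentration tested (going by the name of the read-out)), compound 1 gives 7%, a small read-out. In this assay compound 2 is reported as "not active" (no number reported), so no single number stands for it; it can only be said that it did not show inhibition worth reporting.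

Compound 3 `COC(=O)c1cccc(Cn2nc(OC)oc2=O)c1` is the next compound, not yet measured. It differs from compound 2 in one place: methoxycarbonyl in place of cyano on an aromatic carbon. Going by the values given here, no step between measured compounds is available, so the size of this change cannot be read from the data. Given that compound 1 and compound 2 both sit at or near no inhibition, the expectation for this assay is no step beyond the scatter, in either direction. Compound 3 is therefore expected to give about 5%, within a range of -5% to 15%.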

Compound 3, a percentage reported as inhibition, at one concentration (the size of the read-out at that concentration, not a potency): 20%
Beside the measured number, compound 3's estimate is 15 percentage points below it; measured number outside the range, above it.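

In this assay, methoxycarbonyl in place of nitro on this aromatic carbon gives a number 13 percentage points higher from compound 1 to compound 3 (beyond the scatter) and shows that the read-out at this position does depend on the group it carries. Compound 2 has no number, and the steps from it to the other compounds cannot be read, so the place of the nitrile in this comparison stays undefined. Nothing shown here explains the rise in inhibition.

Going by these compounds, whether an ethoxycarbonyl group, a carboxylic acid or an amide on the same aromatic carbon would raise or lower the read-out remains open. Also open, on these data alone, is how potent compound 3 is, since its 20% describes a single concentration and gives no potency.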